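A Hydroxy Group on the Chain of Compound 1

A few compounds are considered here, and "the series" means these few. Any claim that something is new, unique, unknown or untested is made for them only; others in the source may bear on it.

Compound 1 has the structure `CCCNc1nc(-c2ccccc2)nc2c1nnn2Cc1ccccc1F`. It was tested in an assay on Cerebral cortex for displacement of a labelled ligand from adenosine receptor A1 (Bos taurus) (on this read-out lower numbers stand for stronger inhibition and higher numbers for weaker inhibition), where compound 1 gives 3.2 nM. Among the compounds with values here, that is the only number available here. A second compound, compound 2, with the structure `CCCNc1nc(-c2ccccc2)nc2c1nnn2Cc1ccccc1C(F)(F)F`, was included in the same study, but in this assay compound 2 gives "not determined" (no result reported), so it offers no comparison.

Compound 3 has the structure `OCCCNc1nc(-c2ccccc2)nc2c1nnn2Cc1ccccc1F`. It differs from compound 1 in one place: hydroxy in place of hydrogen on a saturated chain carbon, three bonds along the chain from a nitrogen on an aromatic ring. Within the data shown here, no step between two measured compounds is available to show what such a change does in this assay, so the expectation rests on compound 1 alone and on the nature of the change.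

The change is small in the number of atoms involved, and the rest of the structure is untouched. A modest weakening seems the most likely outcome, but one that may not exceed the usual scatter. The expected step of a 1.9-fold higher number from compound 1 to compound 3 (0.27 log units; within the scatter) is therefore small and toward weaker inhibition. Compound 3 is estimated at 6 nM, within a range from 1.5 nM to 25 nM.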

Compound 3, inhibition constant: 3.7 nM
Compound 3: the middle estimate sits 1.6-fold (0.21 log units) above what was measured; the measured number falls inside the stated range.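

In this assay, the change from propyl to 3-hydroxypropyl gives a 1.2-fold higher number from compound 1 to compound 3 (0.06 log units; within the scatter) on this read-out, so the two compounds cannot be told apart here. Within the data shown here, this is the first readable step at this position, and it shows that, on the core of compound 1, a hydroxy group can replace hydrogen on this saturated chain carbon without moving the number beyond the normal variation between repeated measurements. No independent measurement is available to explain this result, so it describes only what happened to the number and gives no reason for it.

On these data alone, a single substitution says little about the wider range of groups that this chain might accept, so it remains open whether an amine, a carboxylic acid, a methoxy group or a longer chain ending in hydroxy would also leave the number in the same range. As far as these compounds go, it also remains open whether the same result would hold with trifluoromethyl on the benzyl ring, since the step involving compound 2 cannot be read without a number for that compound.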